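A few compounds are considered here, and "the series" means these few. Any claim that something is new, unique, unknown or untested is made for them only; others in the source may bear on it.

Measured so far in a physicochemical assay for solubility; on this read-out lower numbers stand for lower solubility and higher numbers for higher solubility:
- compound 1 `O=C(N[C@@H](CO)C(=O)NO)c1ccc(C#Cc2ccccc2)cc1`: 28000 nM
- compound 2 `NC(=O)C[C@H](NC(=O)c1ccc(C#Cc2ccccc2)cc1)C(=O)NO`: 61000 nM
- compound 3 `CS(=O)(=O)C[C@H](NC(=O)c1ccc(C#Cc2ccccc2)cc1)C(=O)NO`: 2000 nM

Compound 1 stands second highest of the three numbers; compound 2 sits a modest step above it, compound 3 a large step below it. The series varies only the group on the saturated chain carbon two bonds along the chain from the amide-type nitrogen and the carbonyl carbon, while the shared core is kept.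

Compound 4 `CC(C)(NC(=O)c1ccc(C#Cc2ccccc2)cc1)C(=O)NO` is not yet measured. From compound 1 it differs as follows: a group of 7 heavy atoms (4 carbon, 1 nitrogen, 2 oxygen; no ring) in place of a group of 7 heavy atoms (3 carbon, 1 nitrogen, 3 oxygen; no ring), on an amide-type nitrogen. Unlike compounds 2 and 3, the replacement also removes the defined stereocentre and lowers the counts of hydrogen-bond donors and acceptors.

Steps that bear on this: a 2.2-fold higher number from compound 1 to compound 2 (0.34 log units; beyond the scatter), a 14-fold lower number from compound 1 to compound 3 (1.15 log units; beyond the scatter) and a 31-fold lower number from compound 2 to compound 3 (1.48 log units; beyond the scatter). Changes at this one site have moved this assay in both directions, from modest to large. Within the data shown here, no measured step removes the hydroxy outright, so the direction rests on analogy only. A step of moderate size, most likely toward a lower number, is expected: a 2.3-fold lower number from compound 1 to compound 4 (0.37 log units; beyond the scatter). Compound 4 is estimated at 12000 nM, within the range 3000 nM to 45000 nM.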

Compound 4, solubility: 182000 nM
Compound 4: middle estimate off by 15-fold (1.18 log units), on the low side, outside the stated range (above it).
By their numbers in this assay, from the lowest: compound 3; then compound 1; then compound 2; then compound 4.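

In this assay, the change on the amide-type nitrogen to 1-(hydroxycarbamoyl)-1-methylethyl gives a 6.5-fold higher number from compound 1 to compound 4 (0.81 log units; beyond the scatter), and compound 4 now stands at the top of the order of the four numbers. The earlier steps shown here at this site showed only replacements of the hydroxy by other heteroatom-bearing groups, with carbamoyl raising the number and methylsulfonyl lowering it; here a group with no hydroxy, with lower counts of hydrogen-bond donors and acceptors and without the defined stereocentre still gives a higher number, so in this set a high number depends neither on the hydroxy nor on those higher counts. Nothing in the data at hand accounts for the size or direction of this step.

The compounds shown do not separate the loss of the hydroxy from the loss of the defined stereocentre and the arrival of the second methyl, as all of these change together in compound 4. From the compounds shown here alone, how an amine, a carboxylic acid, a longer chain such as ethyl, or a single methyl at this site would read in this assay remains open.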